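The source may report more compounds than this note shows. Statements on the series, on what has been measured and on what is new or still open speak of the compounds shown alone.

Measured in a functional assay on MOLT-4 cells (Homo sapiens) for inhibition; a higher number here means a weaker inhibitor, a lower number a stronger inhibitor:
- Compound 1 `O=C1/C(=C/c2ccc(Cl)cc2)Cc2ccccc21` gives > 500000 nM (a limit)
- Compound 2 `O=C1/C(=C/c2ccc(Br)cc2)Cc2ccccc21` gives > 500000 nM (a limit)
- Compound 3 `O=C1/C(=C/c2ccc(F)cc2)CCc2ccccc21` gives 41200 nM

Compound 3 is the only one of these with an actual number, 41200 nM. The other two results are limits of the assay, not numbers: the limit of > 500000 nM in this assay, at which 2 of the 3 values shown sit. That leaves little to compare.

The next structure is compound 4 `CN(C)c1ccc(/C=C2\CCc3ccccc3C2=O)cc1`, which has dimethylamino in place of fluoro on an aromatic carbon, para to a large group: dimethylamino in place of fluoro on an aromatic carbon. The added group is larger than the one it replaces and brings a hydrogen-bond acceptor, going by the count.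

Going by the values given here, only one measured step is available, a step that the two limits leave unreadable from compound 1 to compound 2, with bromo in place of chloro. It has no readable size, and it involves neither group in the new change. The data therefore give no direction for this swap, and the best starting point is compound 3 at 41200 nM. With no measured basis for a shift, the expected change is no larger than the scatter, though the uncertainty is wide on both sides. The estimated change is a 1.2-fold lower number from compound 3 to compound 4 (0.07 log units; within the scatter). The expected value for compound 4 is 35000 nM, with an estimated range of 9000 nM to 140000 nM.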

Compound 4, half-maximal inhibitory concentration: 2110 nM
The estimate for compound 4 lay 17-fold (1.22 log units) above the measured number; measured number below the stated range.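

In this assay, the aromatic carbon para to a large group proves to be a place where the choice of group matters: dimethylamino in place of fluoro gives a 20-fold lower number from compound 3 to compound 4 (1.29 log units; beyond the scatter). Going by these compounds alone, the one earlier step at such a carbon, bromo in place of chloro between compound 1 and compound 2, cannot be read, since neither result is a number and both compounds stand at the same limit: the limit of > 500000 nM in this assay, at which 2 of the 4 values shown sit. Nothing measured here gives a reason for the size of the new step.

The compounds shown leave open whether dimethylamino itself is needed, or whether another nitrogen group on the same carbon, such as a plain amine or a morpholine, would give a similarly low number. Also open, on these data alone, is how a group without nitrogen, such as methoxy or a carboxylic acid, would read in that place, and whether dimethylamino would have a comparable effect on the core of compound 1.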